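Shortening the Nitrooxy Ester Chain of Compound 2

The source may report more compounds than this note shows. Statements on the series, on what has been measured and on what is new or still open speak of the compounds shown alone.

Of the compounds shown here, three have so far been tested in a functional assay on NCI-H1792 cells (Homo sapiens) for cytotoxicity, read by resazurin assay, with a stated time of 72 h; on this read-out higher numbers stand for weaker inhibition and lower numbers for stronger inhibition. Compound 1, `COc1cc(/C=C/C(=O)OCCCCCO[N+](=O)[O-])ccc1OCCCCCO[N+](=O)[O-]`, reaches only a limit of the assay, > 50000 nM. Compound 3, `O=C(/C=C/c1ccc(OCCCCO[N+](=O)[O-])c(O)c1)OCCCCO[N+](=O)[O-]`, likewise gives only a limit, > 50000 nM. Among the compounds with values here, compound 2, `COc1cc(/C=C/C(=O)OC/C=C/CO[N+](=O)[O-])ccc1O`, gives 4860 nM and therefore stands as the only numerical value among the three. The remaining evidence is the limit of > 50000 nM in this assay, at which 2 of the 3 values shown sit. Compound 4, `COc1cc(/C=C/C(=O)OCCCO[N+](=O)[O-])ccc1O`, has not yet been measured. It differs from compound 2 by a group of 6 heavy atoms (2 carbon, 1 nitrogen, 3 oxygen; no ring) in place of a group of 7 heavy atoms (3 carbon, 1 nitrogen, 3 oxygen; no ring), on a saturated chain carbon bound to an oxygen next to a carbonyl group. Within the data shown here, no measured pair differs in a single place, so no measured step guides the estimate. A modest shift toward weaker inhibition in this assay is expected, possibly within the scatter, giving an expected step of a 1.6-fold higher number from compound 2 to compound 4 (0.22 log units; within the scatter). Compound 4 is accordingly estimated at 8000 nM, with a range from 2500 nM to 25000 nM.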

Compound 4, half-maximal inhibitory concentration: 28500 nM
Estimate against measurement, compound 4: 3.6-fold (0.55 log units) below; measured number above the stated range.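

In this assay, placing 2-(nitrooxy)ethyl on the saturated chain carbon bound to an oxygen next to a carbonyl group gives a 5.9-fold higher number from compound 2 to compound 4 (0.77 log units; beyond the scatter). Within the data shown here, this is the first single-place comparison, and it shows that this position responds to a change in the nitrooxy ester chain. Compound 4 still gives a number rather than a limit, but the step moves it toward the limit reached by others: the limit of > 50000 nM in this assay, at which 2 of the 4 values shown sit.

The compounds shown do not separate the shorter chain from the loss of a chain double bond. As far as these compounds go, how an amine or a longer saturated chain would read at this position also remains open.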